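Compound 3 to compound 4: swapping the aryl group on nitrogen

This account rests on a few compounds, and the source may have more. Where it says the series, first, only, none or still open, it means among the compounds named here.

Values in a functional assay on DU-145 cells (Homo sapiens) for inhibition, read by trypan blue exclusion, with a stated time of 72 h; on this read-out higher numbers stand for weaker inhibition and lower numbers for stronger inhibition:
- compound 1 `Cn1c(=O)c(S(=O)(=O)c2ccc(F)cc2)cc2cnc(Nc3ccc4occc4c3)nc21`: 5000 nM
- compound 2 `Cn1c(=O)c(S(=O)(=O)c2ccc(F)cc2)cc2cnc(Nc3ccc4cc[nH]c4c3)nc21`: 10000 nM
- compound 3 `Cn1c(=O)c(S(=O)(=O)c2ccc(F)cc2F)cc2cnc(Nc3ccc4occc4c3)nc21`: 15000 nM

Compound 3, at 15000 nM, is the highest number of the three, but lies within the scatter of compound 2. The gap to compound 1 is beyond the scatter, a 3.0-fold higher number from compound 1 to compound 3 (0.48 log units; beyond the scatter), though that step is a fluoro change and not a swap of this group.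

Compound 4 `Cn1c(=O)c(S(=O)(=O)c2ccc(F)cc2F)cc2cnc(Nc3ccc4cccc(O)c4n3)nc21` is still unmeasured. Its change is 8-hydroxyquinolin-2-yl in place of 1-benzofuran-5-yl on a nitrogen on an aromatic ring.

The closest measured precedent is a 2.0-fold higher number from compound 1 to compound 2 (0.30 log units; within the scatter), a swap at the same place that stayed within the scatter. Among the measured compounds shown here, no measured compound carries the entering group, so the expectation is loose. The expected step is a 1.5-fold lower number from compound 3 to compound 4 (0.18 log units; within the scatter), with no clear shift beyond the scatter anticipated. For compound 4 the estimated value is 10000 nM, with an expected range of 3000 nM to 30000 nM.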

Compound 4, half-maximal inhibitory concentration: 5000 nM
For compound 4 the middle estimate is 2.0-fold (0.30 log units) above the measured one; the measured number falls inside the stated range.
By their numbers in this assay, from the lowest: compounds 1, 4, 2 and 3 (each within the scatter of the next, the first and the last beyond it).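

In this assay, among the compounds shown here, this is the first swap of the aryl group on the nitrogen to move the number beyond the scatter: it gives a 3.0-fold lower number from compound 3 to compound 4 (0.48 log units; beyond the scatter), whereas the earlier swap at this place gave a 2.0-fold higher number from compound 1 to compound 2 (0.30 log units; within the scatter). The entering 8-hydroxyquinolin-2-yl carries a hydrogen-bond donor and the leaving 1-benzofuran-5-yl carries none, but the series does not separate the hydroxyl from the change of ring. Nothing available explains the lower number.

Open, as far as these compounds go, is whether a methoxy group or an amine in place of the hydroxyl would give a similar number. Also open, from the compounds shown here alone, is whether the step carries over to the sulfonyl aryl group of compound 1.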